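This account rests on a few compounds, and the source may have more. Where it says the series, first, only, none or still open, it means among the compounds named here.

Measured so far:
compound 1, `COc1cc2c(Oc3ccc(NC(=O)c4nn(-c5cccc(F)c5)c(=O)cc4C)cc3F)ccnc2cc1OCCCN1CCC(C)CC1`, in a functional assay on MKN-45 cells (Homo sapiens) for inhibition, read by MTT assay, with a stated time of 72 h (a lower number here means a stronger inhibitor, a higher number a weaker inhibitor), gives 140 nM;
compound 2, `COc1cc2c(Oc3ccc(NC(=O)c4nn(-c5ccc(Cl)cc5)c(=O)cc4C)cc3F)ccnc2cc1OCCCN1CCCC1`, in this assay gives 150 nM.

Compound 2 stands at the higher of the two numbers, though its gap to compound 1 is within the scatter, so the two cannot be told apart. Compound 3, `COc1cc2c(Oc3ccc(NC(=O)c4nn(-c5ccc(Cl)cc5)c(=O)cc4C)cc3F)ccnc2cc1OCCCN1CCC(C)CC1`, differs from compound 2 by 4-methylpiperidin-1-yl in place of pyrrolidin-1-yl on a saturated chain carbon, three bonds along the chain from an oxygen on an aromatic ring. Within the data shown here, no step between measured compounds covers this exchange alone. Since compound 1 already carries the entering ring and gives 140 nM, compound 3 is expected to show no step beyond the scatter, a 1.2-fold lower number from compound 2 to compound 3 (0.06 log units; within the scatter), and is estimated at 130 nM, between 60 nM and 300 nM.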

Compound 3, half-maximal inhibitory concentration: 150 nM
Compound 3: the middle estimate sits 1.2-fold (0.06 log units) below what was measured; measured number inside the range.
By their numbers in this assay, from the lowest: compounds 1, 2 and 3 (each within the scatter of the next).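

In this assay, 4-methylpiperidin-1-yl in place of pyrrolidin-1-yl at this chain position gives no change at the digits printed from compound 2 to compound 3 (within the scatter), so the two rings cannot be told apart here. With 4-methylpiperidin-1-yl held, 4-chlorophenyl in place of 3-fluorophenyl on an aromatic nitrogen gives a 1.1-fold higher number from compound 1 to compound 3 (0.03 log units; within the scatter), so this exchange cannot be told apart either. No evidence on these two exchanges beyond the assay numbers is available. As far as these compounds go, whether morpholin-4-yl or a dimethylamino group in the place of these rings, or an unsubstituted phenyl on the aromatic nitrogen, would give a step beyond the scatter stays open.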